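The compounds below may be only part of what the source reports. "The series", "measured", "known", "first", "only" and "open" are said of these compounds alone.

Working notes on the series, read-out: an ADME assay on microsomes from liver (Rattus norvegicus) for metabolic stability, with a stated time of 30 min, tested at 1 uM; a higher number here means that more of the compound is left, a lower number that less of the compound is left.

- compound 1 `CC[C@@H]1C(=O)N(C)c2cnc(-n3ccnc3-c3ccc(F)cc3)nc2N1C1COC1`: 80%
- compound 2 `CCC1C(=O)N(C)c2cnc(-n3ccnc3-c3ccc(F)cc3)nc2N1c1ccc(F)cc1`: 11%
- compound 3 `CC[C@@H]1C(=O)N(C)c2cnc(-c3cn[nH]c3-c3nccs3)nc2N1[C@H]1CCOC1`: 39%

Compound 2 holds the lowest number of the three, 11%. Compound 3 is the nearest at 39%, and compound 1 is the furthest at 80%. Both gaps lie beyond the scatter of repeated measurements.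

The next compound to be read in this assay is compound 4 `CCC1C(=O)N(C)c2cnc(-n3ccnc3-c3ccc(F)cc3)nc2N1c1ccc(C#N)cc1`. It keeps compound 2 intact except at one place: cyano in place of fluoro on an aromatic carbon. In words, this is cyano in place of fluoro on an aromatic carbon, a change from 4-fluorophenyl to 4-cyanophenyl.

Among the compounds with values here, no measured pair in this small set differs in only one place, so the size of this step has no direct precedent and the expectation is loose. With compound 2 at 11%, little room remains for a fall, so any clear movement is expected to be upward. The estimated step of a number 9 percentage points higher from compound 2 to compound 4 (within the scatter) is expected to be modest and may not clear the scatter.

For compound 4 the expected value is 20%, with an estimated range of 8% to 38%.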

Compound 4, percent of the compound remaining: 48%
Beside the measured number, compound 4's estimate is 28 percentage points below it; the whole stated range lies below it.
By their numbers in this assay, from the lowest: compound 2; then compounds 3 and 4 (each within the scatter of the next); then compound 1.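

In this assay the series gains its first step read at a single place: cyano in place of fluoro on an aromatic carbon gives a number 37 percentage points higher from compound 2 to compound 4 (beyond the scatter) with the rest of the structure unchanged. The earlier compounds shown here differ from one another in more than one place, so they could not show that this carbon, on a six-membered aromatic ring of carbon only and para to a large group, can carry a large step on its own. The shift from 4-fluorophenyl to 4-cyanophenyl is thus a clear single-place change in the compound left in this read-out, although nothing available bears on the reason for it.

Going by these compounds, this is one pair with one replacement, so it gives no trend across groups at this carbon, and it is unknown where a plain hydrogen, a chloro, a methoxy, an amine or a carboxylic acid would fall relative to fluoro and cyano. On these data alone, it also remains open whether the same replacement would give a step of similar size in a compound with a different group on the ring nitrogen or with a different substituent on the shared core.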